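The source may hold more compounds than are shown below. What is called first, only, known or untested is meant among the compounds shown, and "the series" means these compounds.

Measured compounds in a functional assay on MCF7 cells (Homo sapiens) for cytotoxicity, read by MTT assay, with stated times of 6 h and 48 h; a higher number here means a weaker inhibitor, a lower number a stronger inhibitor:
- compound 1 `Cn1c(/C=C/C(=O)c2ccccc2)cc(Br)c1Br`: 35400 nM
- compound 2 `Cn1c(/C=C/C(=O)c2cccc(O)c2)cc(Br)c1Br`: 12800 nM
- compound 3 `Cn1c(/C=C/C(=O)c2cc(O)ccc2O)cc(Br)c1Br`: 320 nM

Compound 2 stands second highest of the three numbers. Its nearest neighbour is compound 1, reached by hydroxy in place of hydrogen on an aromatic carbon, a step of a 2.8-fold lower number from compound 1 to compound 2 (0.44 log units; beyond the scatter). The furthest is compound 3, again by hydroxy in place of hydrogen on an aromatic carbon, a step of a 40-fold lower number from compound 2 to compound 3 (1.60 log units; beyond the scatter).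

Compound 4 `Cn1c(/C=C/C(=O)c2cccc(N)c2)cc(Br)c1Br` differs from compound 2 as follows: amino in place of hydroxy on an aromatic carbon. Neither measured step matches this change; both added a hydroxy, whereas here one group of one heavy atom is swapped for another of one heavy atom, each carrying one donor and one acceptor. The two measured steps show that the phenyl ring substitution moves this assay, but give no reading of a swap between two such groups. A step within the scatter is therefore expected for compound 4, in either direction, as a 1.1-fold lower number from compound 2 to compound 4 (0.03 log units; within the scatter). The estimated value for compound 4 in this assay is 12000 nM, with a range from 4000 nM to 40000 nM.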

Compound 4, half-maximal inhibitory concentration: 12400 nM
Compound 4: middle estimate off by 1.0-fold (0.01 log units), on the low side; the range from low to high includes it.
By their numbers in this assay, from the lowest: compound 3; then compounds 4 and 2 (each within the scatter of the next); then compound 1.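

In this assay, amino in place of hydroxy on an aromatic carbon, meta to a large group, gives no step beyond the scatter (a 1.0-fold lower number from compound 2 to compound 4 (0.01 log units; within the scatter)), so the two groups cannot be told apart at this position. Against the unsubstituted ring, amino in place of hydrogen gives a modest step beyond the scatter (a 2.9-fold lower number from compound 1 to compound 4 (0.46 log units; beyond the scatter)), so the lower number at this position does not depend on hydroxy alone. Nothing available gives a reason why the two groups read alike.

As far as these compounds go, it remains open whether methoxy, dimethylamino or a carboxylic acid at this position would keep the lower number seen with hydroxy and amino. From the compounds shown here alone, it is also open whether amino could replace the added hydroxy of compound 3, where the much larger step arose.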